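Methyl position change on two quinazoline-type scaffolds

The compounds below may be only part of what the source reports. "The series", "measured", "known", "first", "only" and "open" are said of these compounds alone.

Measured so far:
compound 1 `COc1cc2ncnc(Nc3cccc(C)c3)c2cc1OCCCCC(=O)Nc1ccc(S(N)(=O)=O)cc1` — 7460 nM
compound 2 `COc1cc2ncnc(Nc3ccc(C)cc3)c2cc1OCCCCC(=O)Nc1ccc(S(N)(=O)=O)cc1` — 35500 nM
compound 3 `Cc1cccc(Nc2ncnc3ccc(NC(=S)Nc4ccc(S(N)(=O)=O)cc4)cc23)c1` — 23800 nM

All three were tested in a functional assay on A-431 cells (Homo sapiens) for antiproliferative activity, read by MTT assay, with a stated time of 72 h; a higher number here means a weaker inhibitor, a lower number a stronger inhibitor. Compound 1 gives 7460 nM in this assay, compound 2 gives 35500 nM, and compound 3 gives 23800 nM. Compounds 1 and 2 share one core and differ only by 4-methylphenyl in place of 3-methylphenyl on a nitrogen on an aromatic ring; that change gave a 4.8-fold higher number from compound 1 to compound 2 (0.68 log units; beyond the scatter). The difference between the core of compound 1 and the core of compound 3 is not broken down here. Compound 2 and compound 3 lie within the usual scatter of each other, so no order between them can be claimed.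

The unmeasured compound 4 `Cc1ccc(Nc2ncnc3ccc(NC(=S)Nc4ccc(S(N)(=O)=O)cc4)cc23)cc1` is built from compound 3 by the same kind of change, (4-methylphenyl in place of 3-methylphenyl on a nitrogen on an aromatic ring), at a place whose surroundings read the same as in the pair of compounds 1 and 2. Since the change occurs only twice among these compounds, the expectation rests on one step alone. For compound 4 a step of roughly a 3.8-fold higher number from compound 3 to compound 4 (0.58 log units; beyond the scatter) is expected, because compound 1 moving to compound 2 showed a 4.8-fold higher number from compound 1 to compound 2 (0.68 log units; beyond the scatter). Compound 4 is therefore estimated at 90000 nM, with a likely range from 35000 nM to 250000 nM; compound 3 may be reported only as a limit, since weak compounds often fall beyond the tested range.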

Compound 4, half-maximal inhibitory concentration: 40000 nM
Estimate against measurement, compound 4: 2.3-fold (0.35 log units) above; the range from low to high includes it.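

In this assay, putting 4-methylphenyl in place of 3-methylphenyl gives a 1.7-fold higher number from compound 3 to compound 4 (0.23 log units; within the scatter), so on this core the two compounds cannot be told apart. Among these compounds, the size of the step seen on the first core therefore did not carry over to the second, and a step measured on one core proved a poor guide to the other: the same change on two cores in this assay, a 4.8-fold higher number (0.68 log units; beyond the scatter) from compound 1 to compound 2 and a 1.7-fold higher number (0.23 log units; within the scatter) from compound 3 to compound 4, 2.8-fold (0.45 log units) apart, beyond the scatter of two such steps This rests on only two pairs, so it does not show why the steps differ, which part of the cores matters, or whether the small step on the second core has any real direction.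

The compounds shown leave open whether a third core would behave more like the pair of compound 1 and compound 2 or the pair of compound 3 and compound 4. They also leave open how each core would respond if a chlorine atom or an amine stood in place of the methyl group on the phenyl ring.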